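Removing a chloromethyl group in a small cytotoxicity series

A few compounds are considered here, and "the series" means these few. Any claim that something is new, unique, unknown or untested is made for them only; others in the source may bear on it.

Of the compounds shown here, three have been measured so far, and a fourth awaits measurement. Compound 1 `CCCc1ccccc1OS(=O)(=O)c1cccc(NC(=O)NCCCCl)c1` is the reference for one core. In a functional assay on HT-29 cells (Homo sapiens) for cytotoxicity, read by sulforhodamine B assay, with a stated time of 48 h (on this read-out higher numbers stand for weaker inhibition and lower numbers for stronger inhibition), compound 1 gives 14000 nM. Compound 3 `CCCc1ccccc1OS(=O)(=O)c1cccc(NC(=O)NCC)c1` carries the same core with a shorter chain on the urea nitrogen, and in this assay compound 3 gives 25000 nM. The change from compound 1 to compound 3 is hydrogen in place of chloromethyl on a saturated chain carbon, two bonds along the chain from an amide-type nitrogen, and it moves the read-out by a 1.8-fold higher number from compound 1 to compound 3 (0.25 log units; within the scatter).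

Compound 2 `Cc1ccccc1OS(=O)(=O)c1ccc(NC(=O)NCCCCl)cc1` belongs to a second core; the difference between the two cores is not broken down here. In this assay compound 2 gives 26000 nM, which sits close to the value of compound 3 and within scatter of compound 1, so no order among the three can be drawn.

Compound 4 `CCNC(=O)Nc1ccc(S(=O)(=O)Oc2ccccc2C)cc1` is the partner of compound 2 in the same change, (hydrogen in place of chloromethyl on a saturated chain carbon, two bonds along the chain from an amide-type nitrogen). The place of the change is described in the same words for both pairs, so it is taken as the same change. Among the compounds shown it appears twice, once measured and once not.

The expectation for compound 4 rests on the measured pair: the step from compound 2 to compound 4 is expected to be a 1.3-fold higher number from compound 2 to compound 4 (0.10 log units; within the scatter), beside the earlier one, because the same change gave a 1.8-fold higher number from compound 1 to compound 3 (0.25 log units; within the scatter) in the first core, a step within scatter. Compound 4 is therefore estimated at 33000 nM in this assay, with a range from 15000 nM to 70000 nM.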

Compound 4, half-maximal inhibitory concentration: 12000 nM
For compound 4 the middle estimate is 2.8-fold (0.44 log units) above the measured one, outside the stated range (below it).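

In this assay, hydrogen in place of chloromethyl on the second core gives a 2.2-fold lower number from compound 2 to compound 4 (0.34 log units; beyond the scatter), a modest step that lies beyond the scatter, whereas the same change on the first core stays within it. The change therefore does not carry from one core to the other as a fixed step, and a step read on one core is a poor guide to the other in this series: the same change on two cores in this assay, a 1.8-fold higher number (0.25 log units; within the scatter) from compound 1 to compound 3 and a 2.2-fold lower number (0.34 log units; beyond the scatter) from compound 2 to compound 4, 3.9-fold (0.59 log units) apart, beyond the scatter of two such steps

This does not show why the two steps differ, since the cores differ from each other in more than one place and the gap cannot be assigned to any one of those differences; with a single pair per core, it also gives no general rule for removing chloromethyl, and the step on the first core sets no direction of its own.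

The compounds shown leave open how each core responds when a longer chain, an amine or a carboxylic acid stands in place of chloromethyl. They also leave open whether a third core would follow either step, or whether the gap seen here is particular to these two pairs.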